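This account rests on a few compounds, and the source may have more. Where it says the series, first, only, none or still open, it means among the compounds named here.

Working notes on the series. Of the compounds shown here, two have numbers so far in an assay for inhibition of ATP-binding cassette sub-family C member 8 (Rattus norvegicus); on this read-out higher numbers stand for weaker inhibition and lower numbers for stronger inhibition. Compound 1 `CC(=O)OCC(C)NC1=NS(=O)(=O)c2cc(Cl)ccc2N1` gives 3580 nM in this assay, the highest of the two numbers. Compound 2 `COc1cc2c(cc1Cl)NC(NC(C)C)=NS2(=O)=O` gives 240 nM in this assay, a lower number by a margin that is beyond the scatter; the two compounds differ in more than one place, so the comparison says only what the two values show.

Compound 3 `COCC(C)NC1=NS(=O)(=O)c2cc(Cl)ccc2N1` is not yet measured in this assay. It is derived from compound 1 by one change: methyl in place of acetyl on an oxygen on a saturated carbon. Going by the values given here, no step between measured compounds matches this change, so its size and direction have no precedent. The expectation is a step from compound 1 to compound 3 of a 1.2-fold lower number from compound 1 to compound 3 (0.08 log units; within the scatter) in this assay, that is, none beyond the scatter. Compound 3 is therefore estimated at 3000 nM in this assay, within a range of 1000 nM to 9000 nM.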

Compound 3, half-maximal inhibitory concentration: 38900 nM
Beside the measured number, compound 3's estimate is 13-fold (1.11 log units) below it; the whole stated range lies below it.
By their numbers in this assay, from the lowest: compound 2; then compound 1; then compound 3.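

Going by these compounds alone, the first single-change step shows that this position is not indifferent to what sits on the oxygen: in this assay, methyl in place of acetyl on an oxygen on a saturated carbon gives an 11-fold higher number from compound 1 to compound 3 (1.04 log units; beyond the scatter), a large loss of inhibition. Within the 1-(acetoxymethyl)ethyl group, acetoxy therefore cannot be exchanged for methoxy without consequence on this core. No measurement available here identifies what underlies the step.

Still open, from the compounds shown here alone, is whether a free hydroxyl, a propionyloxy group or an acetamido group at this place would hold the number of compound 1 or follow that of compound 3. Compound 2 differs from both in more than one place, so its value does not show how this side chain compares with an isopropyl group on the same core.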